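This account rests on a few compounds, and the source may have more. Where it says the series, first, only, none or still open, it means among the compounds named here.

Measured so far:
compound 1, `CCCCNc1nc(N)nc2ccn(Cc3ccccn3)c12`: > 25 uM
compound 2, `CCCCNc1nc(N)nc2ccn(Cc3cccnc3)c12`: > 25 uM

In an assay on HEK293 cells for agonist activity at Toll-like receptor 8 (Homo sapiens), read by a luciferase reporter, with a stated time of 6 h (on this read-out lower numbers stand for an effect already at smaller amounts and higher numbers for an effect only at larger amounts of compound), compound 1 gives only a limit, > 25 uM. In this assay compound 2 also gives only a limit, > 25 uM. Within the data shown here, the single measured step, a step that the two limits leave unreadable from compound 1 to compound 2, cannot be sized because of the limit of > 25 uM in this assay, at which 2 of the 2 values shown sit. Compound 3, `CCCCNc1nc(N)nc2ccn(Cc3ccncc3)c12`, differs from compound 2 by pyridin-4-yl in place of pyridin-3-yl on a saturated chain carbon bound to an aromatic nitrogen. With no readable step to guide it, the expected step is a step that the limit leaves unreadable from compound 2 to compound 3, nothing beyond the scatter. For compound 3 a value of 30 uM is estimated, between 15 uM and 100 uM, most likely reported again only as a limit.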

Compound 3, minimum effective concentration: > 25 uM
Compound 3 gave a limit, no number; the forecaster's own chance of this, stated with the estimate: 80%; the middle value is on the limit's open side.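

No step can be read among compound 1, compound 2 and compound 3, because each gives only a limit: the limit of > 25 uM in this assay, at which 3 of the 3 values shown sit.

The compounds shown leave open whether pyridin-2-yl, pyridin-3-yl and pyridin-4-yl differ at all in this assay.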